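The source may report more compounds than this note shows. Statements on the series, on what has been measured and on what is new or still open speak of the compounds shown alone.

Of the compounds shown here, three from the same series have been measured in a functional assay on NCI-H226 cells (Homo sapiens) for inhibition, read by sulforhodamine B assay, with a stated time of 48 h; on this read-out lower numbers stand for stronger inhibition of growth and higher numbers for weaker inhibition of growth. Compound 1 `Nc1cc(N)c2nc(-c3ccccc3)c(Oc3ccc(Cl)c(Cl)c3)nc2c1` gives 15100 nM in this assay. Compound 2 `CCOC(=O)[C@H](CCC(=O)O)NC(=O)c1ccc(Sc2nc3cc(N)cc(N)c3nc2-c2ccccc2)cc1` gives 17800 nM in this assay, and compound 3 `COc1cc(CNc2nc3cc(N)cc(N)c3nc2-c2ccccc2)cc(OC)c1OC` gives 10000 nM in this assay. The three numbers lie close together: compound 1 cannot be told apart from either compound 2 or compound 3, since the gap to each falls within the scatter of repeated measurements, so the three compounds appear equally weak on this read-out.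

Compound 4 `Nc1cc(N)c2nc(-c3ccccc3)c(Oc3ccc(F)cc3)nc2c1` has not yet been measured. It differs from compound 1 in one place: 4-fluorophenyl in place of 3,4-dichlorophenyl on an oxygen on an aromatic ring. Going by the values given here, no measured pair in this set carries the same change, so there is no step to lean on. Given that compound 1, compound 2 and compound 3 sit within the scatter of one another despite quite different groups at the variable position, the expected step from compound 1 to compound 4 is a 1.3-fold higher number from compound 1 to compound 4 (0.12 log units; within the scatter), which is no step beyond the scatter, perhaps leaning toward a weaker number. For compound 4 the estimated value in this assay is 20000 nM, with a range from 8000 nM to 50000 nM.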

Compound 4, concentration for 50% growth inhibition: 20400 nM
The estimate for compound 4 lay 1.0-fold (0.01 log units) below the measured number; the measured number falls inside the stated range.
By their numbers in this assay, from the lowest: compounds 3, 1, 2 and 4 (each within the scatter of the next, the first and the last beyond it).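

In this assay, going by these compounds alone, putting 4-fluorophenyl in place of 3,4-dichlorophenyl on an oxygen on an aromatic ring gives a 1.4-fold higher number from compound 1 to compound 4 (0.13 log units; within the scatter), the only step in this set that can be read at a single place. It shows that this exchange, which takes away both chlorine atoms and brings in one fluorine atom while the six-membered aromatic ring and the oxygen stay, does not move the number beyond the scatter. The data shown offer no measurement that could account for this result.

Going by these compounds, the two groups compared here are both halogen-bearing phenyl rings on the same oxygen, so it remains open whether a morpholine or a pyridine ring at this place, or a plain phenyl without any halogen, would give a step beyond the scatter. Equally open, on these data alone, is whether a benzyl group on that oxygen, which would set the aromatic ring one carbon further out from the core of compound 1, would read the same.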